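Methoxy to hydroxy on a shared core: a phenol step

A few compounds are considered here, and "the series" means these few. Any claim that something is new, unique, unknown or untested is made for them only; others in the source may bear on it.

Measured compounds:
Compound 1 `O=C(Nc1cccc(-n2cc(-c3ccncc3)c(-c3ccc(Cl)c(O)c3)n2)c1)Nc1cccc(C(F)(F)F)c1`: 1490 nM
Compound 2 `COc1cc(-c2nn(-c3cccc(NC(=O)Nc4cc(C(F)(F)F)cc(C(F)(F)F)c4)c3)cc2-c2ccncc2)ccc1Cl`: 886 nM

In a functional assay on MDA-MB-435 cells (Homo sapiens) for inhibition, read by sulforhodamine B assay, with a stated time of 48 h (a lower number here means a stronger inhibitor of growth, a higher number a weaker inhibitor of growth), compound 2 gives the lowest of the two numbers; its nearest neighbour is compound 1, whose value lies within the scatter of it. Compound 3 `O=C(Nc1cccc(-n2cc(-c3ccncc3)c(-c3ccc(Cl)c(O)c3)n2)c1)Nc1cc(C(F)(F)F)cc(C(F)(F)F)c1` arises from compound 2 by hydrogen in place of methyl on an oxygen on an aromatic ring. Going by the values given here, no pair of measured compounds differs only at this point, so the size of the step in this assay is unknown; the expectation is for no change beyond the scatter, in either direction. Compound 3 is therefore estimated at 950 nM (range 350 nM to 2600 nM), a step of a 1.1-fold higher number from compound 2 to compound 3 (0.03 log units; within the scatter) that is expected.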

Compound 3, concentration for 50% growth inhibition: 910 nM
Beside the measured number, compound 3's estimate is 1.0-fold (0.02 log units) above it; measured number inside the range.
By their numbers in this assay, from the lowest: compounds 2, 3 and 1 (each within the scatter of the next).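

In this assay the change from methoxy to hydroxy gives a 1.0-fold higher number from compound 2 to compound 3 (0.01 log units; within the scatter), so the methyl on this oxygen can be lost with no step beyond the scatter. Trifluoromethyl in place of hydrogen on an aromatic carbon gives a 1.6-fold lower number from compound 1 to compound 3 (0.21 log units; within the scatter), so that change on the shared core also cannot be told from the scatter. No evidence here bears on either result. As far as these compounds go, whether ethoxy or an amine in place of the hydroxy would read the same remains open, as does whether these small steps would hold in other cell lines.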